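A few compounds are considered here, and "the series" means these few. Any claim that something is new, unique, unknown or untested is made for them only; others in the source may bear on it.

Compound 1 `CC(C)(C)C1=NN(c2ccc(F)cc2)C(c2ccc(O)cc2)C1` carries a fluoro group on one of its two outer rings and a hydroxy group on the other. In an assay on isolated protein for inhibition of protein kinase C zeta type (Homo sapiens), with a stated time of 4 min, tested at 62.5 uM (on this read-out higher numbers stand for more inhibition at the one concentration tested (going by the name of the read-out) and lower numbers for less inhibition), compound 1 gives 95.5%. Compound 2 `CC(C)(C)C1=NN(c2ccc(F)c(F)c2F)C(c2ccc(O)cc2)C1`, which carries three fluoro groups on that same ring, gives 91.7% in this assay. Of the two numbers shown, the one belonging to compound 1 is the larger, yet the gap to compound 2 lies within the usual scatter, so the two readings cannot be told apart.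

Compound 3 `CC(C)(C)C1=NN(c2ccc(O)cc2)C(c2ccc(O)cc2)C1` has not yet been measured. It differs from compound 1 by hydroxy in place of fluoro on an aromatic carbon. Among the measured compounds shown here, no measured pair shows this change, so the expected step from compound 1 to compound 3 rests only on the two readings above, which both sit high on this read-out. The step is therefore expected to be small, at most a mild drop, as a number 7.5 percentage points lower from compound 1 to compound 3 (within the scatter). Compound 3 is estimated to give 88% in this assay, within a range from 70% to 98%.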

Compound 3, a percentage reported as inhibition, at one concentration (the size of the read-out at that concentration, not a potency): 40.9%
The estimate for compound 3 lay 47.1 percentage points above the measured number, and the stated range ends above it.
By their numbers in this assay, from the lowest: compound 3; then compounds 2 and 1 (each within the scatter of the next).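

Hydroxy in place of fluoro gives a number 54.6 percentage points lower from compound 1 to compound 3 (beyond the scatter) in this assay and so shows that this position, para to a large group, does not treat every small group alike. One heavy atom is exchanged for one heavy atom, yet that single exchange on an aromatic carbon moves the read-out well beyond the usual scatter. No measurement at hand explains the loss, so only its size is known.

The compounds shown leave open how other groups would fare on this carbon, such as a methoxy group, a chlorine atom or an amine, and so whether the loss is particular to hydroxy. They also leave open what fluoro in place of the hydroxy on the other outer ring would do.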